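The compounds below may be only part of what the source reports. "The series", "measured", "known", "first", "only" and "open" are said of these compounds alone.

Measured in an ADME assay on TZM cells (Homo sapiens) for cytotoxicity, with a stated time of 1 days (on this read-out higher numbers stand for lower toxicity in this test and lower numbers for higher toxicity in this test), so far:
Compound 1 `COCCNC(=O)/C=C/c1cnc(Nc2ccc(C#N)cc2)nc1Oc1c(C)cc(C#N)cc1C` gives > 213 nM, which is a limit of the assay and not a number.
Compound 2 `Cc1cc(C#N)cc(C)c1Oc1nc(Nc2ccc(C#N)cc2)ncc1/C=C/C(=O)NCCOCCO` gives > 200 nM, likewise a limit.
Compound 3 `Cc1cc(C#N)cc(C)c1Oc1nc(Nc2ccc(C#N)cc2)ncc1/C=C/C(=O)NC1CCN(S(C)(=O)=O)CC1` gives > 175 nM, again a limit.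

Compound 3 therefore stands nowhere exact in this assay: its value is a limit, and the two values beside it are limits as well, namely (the limit of > 175 nM in this assay, at which 1 of the 3 values shown sits), the limit of > 200 nM in this assay, at which 1 of the 3 values shown sits, and (the limit of > 213 nM in this assay, at which 1 of the 3 values shown sits). Within the data shown here, no compound of the three can be placed above or below another.

Compound 4 `Cc1cc(C#N)cc(C)c1Oc1nc(Nc2ccc(C#N)cc2)ncc1/C=C/C(=O)NCC1CCN(S(C)(=O)=O)CC1` differs from compound 3 in one place: (1-(methylsulfonyl)piperidin-4-yl)methyl in place of 1-(methylsulfonyl)piperidin-4-yl on an amide-type nitrogen. The measured steps that touch this position are a step that the two limits leave unreadable from compound 1 to compound 3 and a step that the two limits leave unreadable from compound 2 to compound 3, both exchanges of the group on the amide-type nitrogen, and both left unreadable by the limits on either side; the step that the two limits leave unreadable from compound 1 to compound 2 is unreadable for the same reason. No readable size exists for any change at this position.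

Compound 4 is accordingly expected to remain at a limit in this assay, with the step that the limit leaves unreadable from compound 3 to compound 4 expected to show nothing beyond the scatter. The estimate for compound 4 is 220 nM, within 150 nM to 500 nM.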

Compound 4, half-maximal cytotoxic concentration: > 171 nM
Compound 4 was reported as a limit (the forecaster's own chance of this, stated with the estimate: 85%); the middle value does not contradict the limit.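

In this assay compound 4 gives > 171 nM, a limit of the assay and not a number. The steps linking compound 4 with compound 1, compound 2 and compound 3 cannot be read, as all four values are limits. The compounds shown leave open where any of the four actually lies and whether the group on the amide-type nitrogen changes the read-out at all.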